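A few compounds are considered here, and "the series" means these few. Any claim that something is new, unique, unknown or untested is made for them only; others in the source may bear on it.

Series notes on a functional assay on MCF7 cells (Homo sapiens) for antiproliferative activity, read by MTT assay, with a stated time of 72 h; on this read-out higher numbers stand for weaker inhibition and lower numbers for stronger inhibition. Three compounds carry numbers. Compound 1 `Cc1cc(NCCN2CCN(C)CC2)nc2ccc(NC(=O)c3ccc(Cl)c(Cl)c3)cc12` gives 1700 nM. Compound 2 `CCN1CCN(c2cc(C)c3cc(NC(=O)c4cccnc4)ccc3n2)CC1` gives 26600 nM, and compound 3 `CCN1CCN(c2cc(C)c3cc(NC(=O)c4ccc(C)cc4)ccc3n2)CC1` gives 6740 nM. Among the measured compounds shown here, compounds 2 and 3 share the core of compound 1 but differ from it both in the amine on the core and in the aryl on the carbonyl, so no single-change step links either of them to compound 1; their values simply stand higher. On the numbers shown compound 1 stands lowest of the three, with compound 3 nearest and compound 2 furthest, both gaps beyond the scatter. For the measured compounds named here, the only single-change step measured is a 3.9-fold lower number from compound 2 to compound 3 (0.60 log units; beyond the scatter), which concerns the carbonyl side of the molecule.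

Compound 4 `CCN(CC)c1cc(C)c2cc(NC(=O)c3ccc(Cl)c(Cl)c3)ccc2n1` is not yet measured. It differs from compound 1 by diethylamino in place of (2-(4-methylpiperazin-1-yl)ethyl)amino on an aromatic carbon. Going by the values given here, the step from compound 2 to compound 3 alters the carbonyl substituent, not the amine, so it gives no guidance on this change, and no other step is available. The expectation therefore rests on little, and the range is set wide. Compound 4 is expected at 3500 nM, between 900 nM and 14000 nM, which means an expected 2.1-fold higher number from compound 1 to compound 4 (0.31 log units; beyond the scatter).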

Compound 4, half-maximal inhibitory concentration: > 50000 nM
Compound 4: only a limit was reported; the forecaster's own chance of this, stated with the estimate: 5%; at least 14-fold (1.15 log units) between middle value and limit.
By their numbers in this assay, from the lowest: compound 1; then compound 3; then compound 2. At a limit, above all of these: compound 4.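

Among the compounds shown here, at this position, on an aromatic carbon next to the ring nitrogen, diethylamino in place of (2-(4-methylpiperazin-1-yl)ethyl)amino gives an at least 29-fold higher number from compound 1 to compound 4 (1.46 log units; beyond the scatter), the first single-change reading on the amine side of the molecule in this assay. The aryl on the carbonyl and the shared core stay as in compound 1, so the whole of this large step belongs to the one place, whereas the earlier step between measured compounds concerned only the carbonyl side. Compound 4 reads as a limit of the assay and not as a number, so the step gives only a lower bound on the size of the change: the limit of > 50000 nM in this assay, at which 1 of the 4 values shown sits.

The compounds shown leave open which of the counted differences goes with the loss, since the leaving group differs from diethylamino at once in its six-membered ring, its hydrogen-bond donor and its number of heavy atoms. A dimethylaminoethylamino chain, which has no ring, or a simple ethylamino group on the same carbon would begin to separate these features.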